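Replacing a nitrile with fluorine and methylsulfonyl

A few compounds are considered here, and "the series" means these few. Any claim that something is new, unique, unknown or untested is made for them only; others in the source may bear on it.

Of the compounds shown here, three share a common core and have been tested in an in vitro functional assay on HEK293S cells for agonist activity at Glucose-dependent insulinotropic receptor (Homo sapiens), read by HTRF and cAMP accumulation, with a stated time of 45 min; on this read-out lower numbers stand for an effect already at smaller amounts and higher numbers for an effect only at larger amounts of compound. Compound 1 `CC(C)(C)OC(=O)N1CCN(c2ncc(-c3ccc(OCC#N)cc3)cn2)CC1` gives 78 nM. Compound 2 `C[C@@H]1CN(C(=O)OC(C)(C)C)CCN1c1ncc(OCc2ccc(S(=O)(=O)N(C)C)cc2)cn1` gives 79 nM. Compound 3 `C[C@@H]1CN(C(=O)OC(C)(C)C)CCN1c1ncc(OCc2ccc(C#N)cc2)cn1` gives 39 nM, the lowest number of the three, although compound 1 lies within the usual scatter of it. For the measured compounds named here, the one single-point step seen so far, a 2.0-fold lower number from compound 2 to compound 3 (0.31 log units; beyond the scatter), is a modest change.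

Compound 4 `C[C@@H]1CN(C(=O)OC(C)(C)C)CCN1c1ncc(OCc2ccc(S(C)(=O)=O)cc2F)cn1` is the next compound, not yet measured. It differs from compound 3 in one place: 2-fluoro-4-(methylsulfonyl)phenyl in place of 4-cyanophenyl on a saturated chain carbon bound to an oxygen on an aromatic ring. Going by the values given here, the only step that bears on this is the one from compound 2 to compound 3, where a cyano group in place of a sulfur-bearing dimethylsulfamoyl group lowered the number modestly. Among the compounds with values here, compound 4 goes the other way, bringing a sulfur-bearing methylsulfonyl group back and adding a fluorine for which no measured step exists. The number for compound 4 in this assay is therefore expected to rise modestly, a 1.8-fold higher number from compound 3 to compound 4 (0.25 log units; within the scatter), to an estimated 70 nM, with a likely range from 30 nM to 180 nM.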

Compound 4, half-maximal effective concentration: 3 nM
Compound 4: the middle estimate sits 23-fold (1.37 log units) above what was measured, and the stated range ends above it.
By their numbers in this assay, from the lowest: compound 4; then compounds 3, 1 and 2 (each within the scatter of the next, the first and the last beyond it).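

In this assay, for the compounds shown here, the exchange of the aromatic group on this saturated chain carbon gives a 13-fold lower number from compound 3 to compound 4 (1.11 log units; beyond the scatter) and so outweighs the only earlier step, a 2.0-fold lower number from compound 2 to compound 3 (0.31 log units; beyond the scatter) by a wide margin. The earlier compounds shown here showed only modest movement at this place, whereas this result shows that the group here can shift the number strongly and that a nitrile is not needed for a low number. No measurement shown here explains why this step is so large.

As far as these compounds go, the fluorine and the methylsulfonyl group enter together, so their separate shares in the step remain unknown. A phenyl carrying methylsulfonyl alone, or one carrying both fluorine and a nitrile, would be needed to separate them.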